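Aryl substituent changes on a shared core and cytotoxicity

A few compounds are considered here, and "the series" means these few. Any claim that something is new, unique, unknown or untested is made for them only; others in the source may bear on it.

Measured compounds, with values in a functional assay on 8305C cells (Homo sapiens) for cytotoxicity, read by MTT assay, with a stated time of 24 h; on this read-out higher numbers stand for weaker inhibition and lower numbers for stronger inhibition:
compound 1 `CN1O[C@@H](n2cc(-c3ccccc3)nn2)C[C@@H]1CO` gives 7140 nM
compound 2 `COc1ccc(-c2cn([C@H]3C[C@H](CO)N(C)O3)nn2)cc1` gives 8010 nM
compound 3 `CCCCCc1ccc(-c2cn([C@H]3C[C@H](CO)N(C)O3)nn2)cc1` gives 5960 nM

Compound 3 returns the lowest of the three numbers in this assay, but its separations from compound 1 and compound 2 both sit within the scatter, so no order among the three can be claimed.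

Compound 4 `CN1O[C@@H](n2cc(-c3ccc(F)cc3)nn2)C[C@@H]1CO` follows from compound 3 by the change (fluoro in place of pentyl on an aromatic carbon).

Steps bearing on this change are those that vary the same aromatic position: a 1.2-fold lower number from compound 1 to compound 3 (0.08 log units; within the scatter) and a 1.3-fold lower number from compound 2 to compound 3 (0.13 log units; within the scatter), with a 1.1-fold higher number from compound 1 to compound 2 (0.05 log units; within the scatter) as a further reference. All three are within the scatter, so this aromatic position has so far tolerated hydrogen, methoxy and pentyl without a measurable shift. Fluoro itself has not been tried, and a first-time group carries added uncertainty, but the series gives no ground to expect a step beyond the scatter in either direction in this assay.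

Compound 4 is therefore expected near 6800 nM, within 3500 nM to 13000 nM, which corresponds to an expected step of a 1.1-fold higher number from compound 3 to compound 4 (0.06 log units; within the scatter).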

Compound 4, half-maximal inhibitory concentration: 6760 nM
Estimate against measurement, compound 4: 1.0-fold (0.00 log units) above, and the stated range covers the measured number.
By their numbers in this assay, from the lowest: compounds 3, 4, 1 and 2 (each within the scatter of the next).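

In this assay, fluoro joins hydrogen, methoxy and pentyl as a fourth group on this aromatic carbon, and all its steps stay within the scatter: (a 1.1-fold higher number from compound 3 to compound 4 (0.05 log units; within the scatter)), (a 1.2-fold lower number from compound 2 to compound 4 (0.07 log units; within the scatter)) and (a 1.1-fold lower number from compound 1 to compound 4 (0.02 log units; within the scatter)). Even the exchange of pentyl, with 5 heavy atoms, for fluoro, with 1 heavy atom, produces no measurable shift, so across these four compounds the number shows no dependence on the group at this place. No supporting measurement is available to explain this flat result.

The compounds shown leave open whether an amine, a carboxylic acid or a chain longer than pentyl on this aromatic carbon would give a step beyond the scatter. They also leave open whether any change elsewhere on the shared core would do so.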